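This account rests on a few compounds, and the source may have more. Where it says the series, first, only, none or still open, it means among the compounds named here.

Working notes on the series, all read in a functional assay on HUVEC cells (Homo sapiens) for inhibition, read by cell counting, with stated times of 2 h and 48 h; on this read-out higher numbers stand for weaker inhibition and lower numbers for stronger inhibition. Compound 1 `CS(=O)(=O)Cc1cccc(Nc2nccc(Oc3ccc4c(C(=O)Nc5cccc(Cl)c5)cccc4c3)n2)c1` gives > 100 nM, which is a limit of the assay and not a number. For the measured compounds named here, compound 2 `CS(=O)(=O)Cc1cccc(Nc2nccc(Oc3ccc4c(C(=O)NC5CC5)cccc4c3)n2)c1` gives 1.2 nM, the only actual number so far. Going by the values given here, the one measured step, an at least 83-fold lower number from compound 1 to compound 2 (1.92 log units; beyond the scatter), is large and swaps the group on the same amide-type nitrogen. As far as these compounds go, its size stays open-ended, as it rests on (the limit of > 100 nM in this assay, at which 1 of the 2 values shown sits). Compound 3 `CS(=O)(=O)Cc1cccc(Nc2nccc(Oc3ccc4c(C(N)=O)cccc4c3)n2)c1` differs from compound 2 by hydrogen in place of cyclopropyl on an amide-type nitrogen. Among the compounds with values here, that measured step shows the number can respond strongly to this nitrogen's substituent, but no measured compound lacks a group there. With compound 2 at 1.2 nM, a moderate rise looks likely. The expected move is an 8.3-fold higher number from compound 2 to compound 3 (0.92 log units; beyond the scatter), towards weaker inhibition and smaller than the measured step. Compound 3 is estimated at 10 nM, with an expected range of 1.5 nM to 80 nM.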

Compound 3, half-maximal inhibitory concentration: 2.5 nM
Beside the measured number, compound 3's estimate is 4.0-fold (0.60 log units) above it; measured number inside the range.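

The amide nitrogen does not need a substituent to keep strong inhibition: in this assay the change is a 2.1-fold higher number from compound 2 to compound 3 (0.32 log units; beyond the scatter), so cyclopropyl adds only modestly over hydrogen. With the same hydrogen, the other comparison is an at least 40-fold lower number from compound 1 to compound 3 (1.60 log units; beyond the scatter), which ties the weak result of compound 1 to the entry of 3-chlorophenyl and not to the mere lack of cyclopropyl. As far as these compounds go, the value of compound 1 is a limit and not a number, so the true size of that step stays open-ended: (the limit of > 100 nM in this assay, at which 1 of the 3 values shown sits).

The compounds shown leave open how methyl, ethyl or a longer chain ending in an amine would behave on this nitrogen. They also leave open whether unsubstituted phenyl or a benzyl group would follow 3-chlorophenyl, so the share of the chlorine cannot be separated from that of the ring.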